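Chloro for Methoxy: Expected Cytotoxicity of Compound 4

This account rests on a few compounds, and the source may have more. Where it says the series, first, only, none or still open, it means among the compounds named here.

Measured compounds:
compound 1, `COc1ccc(-c2csc(NC(=O)CN3CCN(c4cc(=O)[nH]c5ccc(F)cc45)CC3)n2)cc1`, 16900 nM
compound 2, `O=C(CN1CCN(c2cc(=O)n(-c3ccccc3)c3ccccc23)CC1)Nc1nc(-c2ccc(Cl)cc2)cs1`, 30200 nM
compound 3, `COc1ccc(-c2csc(NC(=O)CN3CCN(c4cc(=O)n(-c5ccccc5)c5ccccc45)CC3)n2)cc1`, 8110 nM

Three compounds have been run in a functional assay on T47D cells (Homo sapiens) for cytotoxicity, read by MTT assay, with a stated time of 3 h; on this read-out higher numbers stand for weaker inhibition and lower numbers for stronger inhibition. Compound 3 gives 8110 nM, compound 1 gives 16900 nM and compound 2 gives 30200 nM. Compounds 3 and 2 differ in one place, (chloro in place of methoxy on an aromatic carbon), and this assay records a 3.7-fold higher number from compound 3 to compound 2 (0.57 log units; beyond the scatter). Compounds 1 and 3 share the remaining parts but differ in their cores; the difference between the two cores is not broken down here.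

Compound 4, `O=C(CN1CCN(c2cc(=O)[nH]c3ccc(F)cc23)CC1)Nc1nc(-c2ccc(Cl)cc2)cs1`, has not yet been measured. It relates to compound 1 as compound 2 relates to compound 3: chloro in place of methoxy on an aromatic carbon. The two places are described in identical words, so this is the same change. Because compound 3 to compound 2 showed a 3.7-fold higher number from compound 3 to compound 2 (0.57 log units; beyond the scatter), the step from compound 1 to compound 4 is expected to be of similar size, about a 3.0-fold higher number from compound 1 to compound 4 (0.47 log units; beyond the scatter), though on a different core the transfer is uncertain. Compound 4 is estimated at 50000 nM, with a plausible range from 20000 nM to 130000 nM.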

Compound 4, half-maximal inhibitory concentration: 2730 nM
Beside the measured number, compound 4's estimate is 18-fold (1.26 log units) above it; the measured number lies below the stated range.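

In this assay, chloro in place of methoxy gives a 6.2-fold lower number from compound 1 to compound 4 (0.79 log units; beyond the scatter), so on this core the change lowers the number, whereas on the core of compound 3 it raises it. The two steps point in opposite directions, and the gap between them is larger than repeat measurements would explain: the same change on two cores in this assay, a 3.7-fold higher number (0.57 log units; beyond the scatter) from compound 3 to compound 2 and a 6.2-fold lower number (0.79 log units; beyond the scatter) from compound 1 to compound 4, 23-fold (1.36 log units) apart, beyond the scatter of two such steps

In this series, then, the effect of going from 4-methoxyphenyl to 4-chlorophenyl depends on the core that carries it, but this rests on one pair per core and does not show which feature of the two cores decides the direction.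

The compounds shown leave open whether other groups in the same place, such as a fluoro, a methyl or a nitrile, would also behave differently on the two cores. On these data alone, it also remains open how far the fluoro on the core of compound 1 and the phenyl on the core of compound 3 each contribute to the reversal.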